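This account rests on a few compounds, and the source may have more. Where it says the series, first, only, none or still open, it means among the compounds named here.

Three esters of this series have numbers in a functional assay on SW1573 cells (Homo sapiens) for antiproliferative activity, read by sulforhodamine B assay, with a stated time of 48 h (on this read-out higher numbers stand for weaker inhibition of growth and lower numbers for stronger inhibition of growth), and they sit close together. Compound 1, `CC(C)C(C#CC(=O)OC(C)(C)C)O/C=C/C(=O)OC(C)(C)C`, with its tert-butyl esters, gives 4800 nM. Compound 2, `COC(=O)C#CC(C[C@@H](C)CCC=C(C)C)O/C=C/C(=O)OC`, which carries a long branched chain at the carbon that bears the alkyne, gives 2200 nM. Compound 3, `CCCCCC(C#CC(=O)OC)O/C=C/C(=O)OC`, which carries a pentyl chain at that carbon and two methyl esters, gives 1700 nM. Compound 3 thus has the lowest of the three numbers, but the gap to compound 2 lies within the scatter, so no order between the two can be claimed; only the gap to compound 1 lies beyond the scatter.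

Compound 4 is `CCC(C#CC(=O)OC)O/C=C/C(=O)OC`. It keeps the two methyl esters and the alkyne of compound 3 and differs in one place only: hydrogen in place of propyl on a saturated chain carbon, three bonds along the chain from an oxygen on an unsaturated carbon and a triple-bonded carbon. Within the data shown here, nothing among the measured compounds isolates this change, so there is no measured step to lean on. The account nevertheless expects a modest loss of potency. The two measured compounds with methyl esters and a long chain, compound 2 at 2200 nM and compound 3 at 1700 nM, give the two lowest numbers. The expected step of a 2.1-fold higher number from compound 3 to compound 4 (0.31 log units; beyond the scatter) is therefore toward a higher number. Compound 4 is estimated to give 3500 nM in this assay, with a range from 1500 nM to 8000 nM.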

Compound 4, concentration for 50% growth inhibition: 540 nM
The estimate for compound 4 lay 6.5-fold (0.81 log units) above the measured number; measured number outside the range, below it.
By their numbers in this assay, from the lowest: compound 4; then compounds 3 and 2 (each within the scatter of the next); then compound 1.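

In this assay, among these compounds, the change from pentyl to ethyl on this saturated chain carbon, with the two methyl esters and the alkyne kept, gives a 3.1-fold lower number from compound 3 to compound 4 (0.50 log units; beyond the scatter) and is the first single change that can be read. It shows that the number at this position responds to chain length, and that the removal of propyl goes with stronger inhibition of growth rather than weaker. A long chain at this carbon is therefore not needed for the activity of this pair, and the shorter chain is the better of the two, but nothing measured here accounts for the size or direction of the step.

On these data alone, two chain lengths on one ester pattern do not make a trend, so it remains open whether the number keeps falling with a methyl group or a lone hydrogen at this carbon, or whether a butyl or propyl chain lies on the same line. Also open, as far as these compounds go, are whether the step holds with tert-butyl esters in place of the methyl esters, and how a phenyl ring or a chain ending in an amine or a hydroxyl group would read at this position.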